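Methoxy added beside methoxy: a small step expected

The source may hold more compounds than are shown below. What is called first, only, known or untested is meant among the compounds shown, and "the series" means these compounds.

Three thiosemicarbazide-linked compounds were tested in a functional assay on B16-F10 cells (Mus musculus) for inhibition, read by colorimetric assay and MTT assay, with a stated time of 72 h; a higher number here means a weaker inhibitor, a lower number a stronger inhibitor. Compound 1 `COc1cc(C(=O)NNC(=S)Nc2csc(-c3ccc(C)cc3)c2)cc(OC)c1OC` gives 13000 nM, and compound 3 `COc1cc(OC)cc(C(=O)NNC(=S)Nc2csc(-c3ccc(C)cc3)c2)c1` gives 13000 nM. The two differ by methoxy in place of hydrogen on an aromatic carbon, and that change produced no change at the digits printed from compound 3 to compound 1 (within the scatter). Compound 2 `COc1ccc(C(=O)NNC(=S)Nc2csc(-c3ccccc3)c2)cc1` gives 33000 nM in this assay, the highest number of the three, with the gap to compound 1 and to compound 3 beyond the usual scatter in both cases. The difference between the cores of compound 2 and compound 3 is not broken down here.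

Compound 4 `COc1ccc(C(=O)NNC(=S)Nc2csc(-c3ccccc3)c2)cc1OC` has not yet been measured in this assay. It is built from compound 2 by methoxy in place of hydrogen on an aromatic carbon. For the measured compounds named here, this is the same kind of change as the one from compound 3 to compound 1, but not the same: in compound 4 the entering methoxy sits ortho to a methoxy group and meta to a large group, whereas in compound 1 it sits ortho to two methoxy groups and para to a large group.

Because the matching change gave no change at the digits printed from compound 3 to compound 1 (within the scatter), the step from compound 2 to compound 4 is expected to be small, about a 1.3-fold lower number from compound 2 to compound 4 (0.12 log units; within the scatter). Compound 4 is estimated to give 25000 nM in this assay. The estimate for compound 4 is bounded by 8000 nM and 70000 nM.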

Compound 4, half-maximal inhibitory concentration: 9000 nM
Compound 4: middle estimate off by 2.8-fold (0.44 log units), on the high side; the measured number falls inside the stated range.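

On the core of compound 2, in this assay, methoxy in place of hydrogen on an aromatic carbon gave a 3.7-fold lower number from compound 2 to compound 4 (0.56 log units; beyond the scatter), a modest step in the direction of a stronger inhibitor. The same change therefore did not carry over at one size from one core to the other, and the two steps differ by more than repeated measurements would explain: the same change on two cores in this assay, no change at the digits printed (within the scatter) from compound 3 to compound 1 and a 3.7-fold lower number (0.56 log units; beyond the scatter) from compound 2 to compound 4, 3.7-fold (0.56 log units) apart, beyond the scatter of two such steps. This shows only that, in these two pairs, the effect of adding a methoxy cannot simply be transferred between cores; with just two pairs, which also differ in the rest of the structure and in the groups already on the ring, it does not show which of those differences sets the size of the step, nor that the step would be larger on any other core.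

The compounds shown leave open whether a hydroxyl, an amine or a carboxylic acid on the same aromatic carbon of compound 2 would give a step like that of the methoxy. They also leave open whether a longer chain in place of the entering methoxy would keep, lose or extend the gain seen in compound 4.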